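Fluoro in Place of Hydrogen on Compound 1

The compounds below may be only part of what the source reports. "The series", "measured", "known", "first", "only" and "open" are said of these compounds alone.

Three compounds have been measured so far:

compound 1 `CN(C)C(=O)c1cc2cnc(Nc3ccc(NC(=O)C4(C(=O)Nc5ccccc5)CC4)cc3)nc2n1C1CCCC1` gives 93.9%
compound 2 `CN(C)C(=O)c1cc2cnc(Nc3ccc(NC(=O)C4(C(=O)Nc5cccc(C(F)(F)F)c5)CC4)cc3)nc2n1C1CCCC1` gives 92.7%
compound 3 `CN(C)C(=O)c1cc2cnc(Nc3ccc(NC(=O)C4(C(=O)Nc5cccc(Cl)c5)CC4)cc3)nc2n1C1CCCC1` gives 92.6%

All three share one core and differ only in a substituent on the phenylcarbamoyl ring. In a functional assay on T47D cells (Homo sapiens) for inhibition, read by CCK-8 assay, with a stated time of 72 h, tested at 10 uM (on this read-out lower numbers stand for less inhibition of growth and higher numbers for more inhibition of growth at the one concentration tested), compound 1 stands highest of the three numbers, but only by a margin that means nothing: a number 1.2 percentage points lower from compound 1 to compound 2 (within the scatter) and a number 1.3 percentage points lower from compound 1 to compound 3 (within the scatter) both fall inside the usual scatter, and so does a number 0.1 percentage points lower from compound 2 to compound 3 (within the scatter). On these numbers the three compounds cannot be told apart.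

Compound 4 `CN(C)C(=O)c1cc2cnc(Nc3ccc(NC(=O)C4(C(=O)Nc5ccc(F)cc5)CC4)cc3)nc2n1C1CCCC1` has not yet been measured. Against compound 1 its change is fluoro in place of hydrogen on an aromatic carbon. The two measured steps that bear on it, from compound 1 to compound 2 and from compound 1 to compound 3, each put a group onto that same ring and moved the number by amounts within the scatter. With growth inhibition already near complete for compound 1, a change beyond the scatter seems unlikely in either direction.

The estimate for compound 4 is therefore 92.5%, with a range of 85% to 97%, which means an expected step of a number 1.4 percentage points lower from compound 1 to compound 4 (within the scatter).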

Compound 4, percent growth inhibition at one concentration: 105%
Compound 4: middle estimate off by 12.5 percentage points, on the low side, outside the stated range (above it).
By their numbers in this assay, from the lowest: compounds 3, 2 and 1 (each within the scatter of the next); then compound 4.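

In this assay, among the compounds shown here, fluoro on an aromatic carbon para to a large group gives a number 11.1 percentage points higher from compound 1 to compound 4 (beyond the scatter), the first change on this ring to move the number beyond the scatter, and it shows that the read-out still had room above compound 1, with compound 4 at 105%. The same ring had looked insensitive while only 3-chlorophenyl and 3-(trifluoromethyl)phenyl stood in place of phenyl, yet the 4-fluorophenyl compound also stands clear of both, with a number 12.4 percentage points higher from compound 3 to compound 4 (beyond the scatter) and a number 12.3 percentage points higher from compound 2 to compound 4 (beyond the scatter), so the choice of group and place on this ring can matter. Nothing shown here gives a measured reason for the rise.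

Compound 4 differs from compounds 2 and 3 in both the group and its place on the ring, so the compounds shown do not separate the role of fluoro from that of the place; 3-fluorophenyl, 4-chlorophenyl, or a methoxy or an amine on the same carbon would bear on this. On these data alone, with only one concentration tested, it also remains open whether the gap between compound 4 and compound 1 would hold at lower concentrations.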